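Compound 3 to compound 4: a longer chain end

A few compounds are considered here, and "the series" means these few. Any claim that something is new, unique, unknown or untested is made for them only; others in the source may bear on it.

In a functional assay on K562 cells (Homo sapiens) for antiproliferative activity (a higher number here means a weaker inhibitor of growth, a lower number a stronger inhibitor of growth), compound 3 `CC(C)(C)C(=O)OCC1(CO)C/C(=C\CCCCCCCCCCCO)C(=O)O1` gives 1.09 ug/mL. Compound 2 `CCCCCOCCCCCCC/C=C1\CC(CO)(COC(=O)C(C)(C)C)OC1=O` gives 1.15 ug/mL, within the scatter of that number, and compound 1 `COCCCCCCCCCCCCCCC/C=C1\CC(CO)(COC(=O)C(C)(C)C)OC1=O` gives 0.189 ug/mL. Compound 4 `CC(C)(C)C(=O)OCCCCCCCCCCCCCCC/C=C1\CC(CO)(COC(=O)C(C)(C)C)OC1=O` differs from compound 3 as follows: 4-(((tert-butyl)carbonyl)oxy)butyl in place of hydroxy on a saturated chain carbon, ten or more bonds along the chain from a double-bonded chain carbon. Within the data shown here, the nearest precedent is a 5.8-fold higher number from compound 1 to compound 3 (0.76 log units; beyond the scatter), with hydroxy in place of 4-methoxybutyl at the same place, here read in the opposite sense. The step of a 6.1-fold higher number from compound 1 to compound 2 (0.78 log units; beyond the scatter) is of similar size, while a 1.1-fold lower number from compound 2 to compound 3 (0.02 log units; within the scatter) stays within the scatter. Among the measured compounds shown here, no measured compound carries the entering group, so this transfer is uncertain. A move to a lower number is expected, a 2.7-fold lower number from compound 3 to compound 4 (0.44 log units; beyond the scatter). The estimate for compound 4 is 0.4 ug/mL, with an expected range of 0.12 ug/mL to 1.3 ug/mL.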

Compound 4, concentration for 50% growth inhibition: 0.352 ug/mL
Estimate against measurement, compound 4: 1.1-fold (0.06 log units) above; the measured number falls inside the stated range.
By their numbers in this assay, from the lowest: compounds 1 and 4 (each within the scatter of the next); then compounds 3 and 2 (each within the scatter of the next).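

In this assay, 4-(((tert-butyl)carbonyl)oxy)butyl in place of hydroxy gives a 3.1-fold lower number from compound 3 to compound 4 (0.49 log units; beyond the scatter), so at this place an ester-capped longer chain end also sits with the lower numbers, not only the methoxy-ended chain of compound 1. With (tert-butyl)carbonyl in place of methyl, a 1.9-fold higher number from compound 1 to compound 4 (0.27 log units; within the scatter) lies within the scatter, so these two chain ends are not separated here. Nothing measured explains either step. Chain length and the end group change together from compound 3 to compound 4, so their separate contributions stay open. A free hydroxy, an amine or a carboxylic acid at the end of the longer chain would address this.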